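The source may hold more compounds than are shown below. What is called first, only, known or untested is meant among the compounds shown, and "the series" means these compounds.

Measured compounds in a functional assay on KB cells (Homo sapiens) for antiproliferative activity, read by MTT assay, with a stated time of 72 h; on this read-out lower numbers stand for stronger inhibition and higher numbers for weaker inhibition:
- compound 1 `CN(C(=O)C(C)(C)C)c1ccc2[nH]c(-c3n[nH]c4ccccc34)cc2n1`: 8390 nM
- compound 2 `CN(C(=O)CCc1ccccc1)c1ccc2[nH]c(-c3n[nH]c4ccccc34)cc2n1`: 7380 nM

Both measured compounds carry the same core and differ only in the acyl group on the amide. Within the data shown here, the one step available, a 1.1-fold lower number from compound 1 to compound 2 (0.06 log units; within the scatter), falls within the scatter, so the change from tert-butyl to phenethyl on the carbonyl carbon leaves the read-out essentially unchanged. Compound 2 gives the lowest of the two numbers, but its neighbour compound 1 sits within the scatter of it, so no ordering between the two can be claimed.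

Compound 3 `COc1ccc(C(=O)N(C)c2ccc3[nH]c(-c4n[nH]c5ccccc45)cc3n2)cc1` is not yet measured. It differs from compound 2 by 4-methoxyphenyl in place of phenethyl on a carbonyl carbon. Among the measured compounds shown here, no measured step exchanges a phenethyl for an aryl group at this position, so the only guidance is that the one acyl variation seen so far, from compound 1 to compound 2, moved nothing beyond the scatter.

On that basis the step of a 1.1-fold lower number from compound 2 to compound 3 (0.02 log units; within the scatter) is expected to stay within the scatter. Compound 3 is therefore estimated at 7000 nM, with a range from 2500 nM to 20000 nM.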

Compound 3, half-maximal inhibitory concentration: 12900 nM
Beside the measured number, compound 3's estimate is 1.8-fold (0.27 log units) below it; the range from low to high includes it.
By their numbers in this assay, from the lowest: compounds 2, 1 and 3 (each within the scatter of the next).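

In this assay, among these compounds, the first acyl group with its aromatic ring directly on the carbonyl carbon gives a 1.7-fold higher number from compound 2 to compound 3 (0.24 log units; within the scatter) and a 1.5-fold higher number from compound 1 to compound 3 (0.19 log units; within the scatter). Both steps lie within the scatter, so tert-butyl, phenethyl and 4-methoxyphenyl cannot be told apart at this position on this read-out, even though 4-methoxyphenyl brings an oxygen and a hydrogen-bond acceptor that phenethyl does not have. No measured information is at hand that bears on this result.

The compounds shown leave open whether any group on this carbonyl carbon can move the read-out beyond the scatter, for example an unsubstituted phenyl, a chain longer than phenethyl, or an acyl group carrying an amine or a carboxylic acid. They also leave open whether the read-out responds to any change outside the acyl group, as everything else is shared by all three compounds.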